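Benzofuran for furan on two related nucleoside cores

The compounds below may be only part of what the source reports. "The series", "measured", "known", "first", "only" and "open" are said of these compounds alone.

Compound 1 `COc1ncnc2c1c(-c1ccoc1)cn2[C@@H]1O[C@H](CO)[C@@H](O)[C@H]1O` and compound 2 `COc1ncnc2c1c(-c1cc3ccccc3o1)cn2[C@@H]1O[C@H](CO)[C@@H](O)[C@H]1O` share one core. In a functional assay on K562 cells (Homo sapiens), read by MTT assay, with a stated time of 72 h (a higher number here means a weaker inhibitor, a lower number a stronger inhibitor), compound 1 gives 2820 nM, and compound 2 gives 13100 nM. The change made between them, (1-benzofuran-2-yl in place of furan-3-yl on an aromatic carbon), produced a 4.6-fold higher number from compound 1 to compound 2 (0.67 log units; beyond the scatter). Compound 3 `Nc1nc(N)c2c(-c3ccoc3)cn([C@@H]3O[C@H](CO)[C@@H](O)[C@H]3O)c2n1` rests on a second core; the difference between the two cores is not broken down here. In this assay compound 3 reaches only a limit, > 20000 nM, which is the limit of > 20000 nM in this assay, at which 1 of the 3 values shown sits. Compound 4 `Nc1nc(N)c2c(-c3cc4ccccc4o3)cn([C@@H]3O[C@H](CO)[C@@H](O)[C@H]3O)c2n1` carries the same kind of change on the second core, (1-benzofuran-2-yl in place of furan-3-yl on an aromatic carbon), at a place described in the same words as before. For compound 4 the expected step is a step that the limit leaves unreadable from compound 3 to compound 4, a further weakening, resting on a 4.6-fold higher number from compound 1 to compound 2 (0.67 log units; beyond the scatter). Compound 4 is therefore expected to give 60000 nM, with a range of 20000 nM to 200000 nM, most likely again recorded only as a limit.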

Compound 4, half-maximal inhibitory concentration: > 20000 nM
Compound 4 gave a limit, no number; the forecaster's own chance of this, stated with the estimate: 90%; the middle value lies beyond the limit too.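

In this assay compound 4 gives only a limit, > 20000 nM, as compound 3 does, so no step between them can be read: the limit of > 20000 nM in this assay, at which 2 of the 4 values shown sit.

On these data alone, whether 1-benzofuran-2-yl in place of furan-3-yl weakens inhibition on this core remains open.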